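A few compounds are considered here, and "the series" means these few. Any claim that something is new, unique, unknown or untested is made for them only; others in the source may bear on it.

Measured so far:
Compound 1 `CCN(CC)CCNC(=O)c1cc(C2CC2)nc2c1cnn2C(C)C` gives 53600 nM in an ADME assay on Vero cells (Chlorocebus sabaeus) for cytotoxicity, read by neutral red uptake, with a stated time of 3 days; on this read-out higher numbers stand for lower toxicity in this test and lower numbers for higher toxicity in this test.
Compound 2 `CC(CN(C)C)NC(=O)c1cc(C2CC2)nc2c1cnn2C(C)C` gives in this assay only a limit, > 300000 nM.

Going by the values given here, compound 2 thus stands at the limit of > 300000 nM in this assay, at which 1 of the 2 values shown sits, and the one measured step, an at least 5.5-fold higher number from compound 1 to compound 2 (0.74 log units; beyond the scatter), already runs toward that ceiling. Compound 3 `CC(C)n1ncc2c(C(=O)NC3CCN(C)C3)cc(C3CC3)nc21` differs from compound 2 by 1-methylpyrrolidin-3-yl in place of 1-((dimethylamino)methyl)ethyl on an amide-type nitrogen. Among the compounds with values here, no measured step covers a change of this kind, so nothing indicates a direction away from the limit. The step of an at least 1.2-fold lower number from compound 2 to compound 3 (0.07 log units; that floor lies within the scatter) is expected to stay within the scatter. Compound 3 is estimated at 250000 nM, between 100000 nM and 600000 nM, and will most likely again be reported only as a limit.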

Compound 3, half-maximal cytotoxic concentration: 33800 nM
Compound 3: middle estimate off by 7.4-fold (0.87 log units), on the high side, outside the stated range (below it).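

The change on the amide-type nitrogen keeps the atoms of the group and adds one five-membered non-aromatic ring, yet it brings an at least 8.8-fold lower number from compound 2 to compound 3 (0.94 log units; beyond the scatter) in this assay. Against the open chain of compound 1, the ring gives a 1.6-fold lower number from compound 1 to compound 3 (0.20 log units; within the scatter), so these two cannot be separated. Compound 2 alone remains at a limit, not a number: the limit of > 300000 nM in this assay, at which 1 of the 3 values shown sits.

On these data alone, whether that limit is tied to 1-((dimethylamino)methyl)ethyl alone stays open. A piperidine ring or a longer chain ending in a primary amine on the same amide-type nitrogen would bear on this.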